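Methoxy in place of hydrogen on the aromatic ring

The compounds below may be only part of what the source reports. "The series", "measured", "known", "first", "only" and "open" are said of these compounds alone.

Measured in a functional assay on BV-173 cells (Homo sapiens) for cytotoxicity, read by MTT assay, with a stated time of 72 h; on this read-out higher numbers stand for weaker inhibition and lower numbers for stronger inhibition:
compound 1 `COc1ccccc1N1CCN(Cn2c(=O)oc3cc(C(=O)/C=C/c4ccccc4)ccc32)CC1` gives 9200 nM
compound 2 `O=C(/C=C/c1ccccc1)c1ccc2c(c1)oc(=O)n2CN1CCN(Cc2ccccc2)CC1` gives 9400 nM
compound 3 `COc1ccc(/C=C/C(=O)c2ccc3c(c2)oc(=O)n3CN2CCCCC2)cc1` gives 15300 nM

Compound 1 has the smallest number of the three, but compound 2 and compound 3 both lie within the scatter of it. Within the data shown here, the only one-place step is a 1.0-fold higher number from compound 1 to compound 2 (0.01 log units; within the scatter), which concerns the amine nitrogen and not the change at hand.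

Compound 4 `COc1ccc(/C=C/C(=O)c2ccc3c(c2)oc(=O)n3CN2CCN(c3ccccc3OC)CC2)cc1` differs from compound 1 by methoxy in place of hydrogen on an aromatic carbon. Among the measured compounds shown here, no measured step tests this change; compound 3 carries the same 4-methoxyphenyl with a different amine, and its value and that of compound 1 sit within the scatter of each other. In this assay, therefore, compound 4 is expected to show no step beyond the scatter, a 1.1-fold higher number from compound 1 to compound 4 (0.04 log units; within the scatter). The estimate for compound 4 is 10000 nM, ranging from 5000 nM to 20000 nM.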

Compound 4, half-maximal inhibitory concentration: 5400 nM
For compound 4 the middle estimate is 1.9-fold (0.27 log units) above the measured one; the range from low to high includes it.
By their numbers in this assay, from the lowest: compounds 4, 1, 2 and 3 (each within the scatter of the next, the first and the last beyond it).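

Among these compounds, the step from hydrogen to methoxy on the aromatic carbon para to a large group, read in this assay, is a 1.7-fold lower number from compound 1 to compound 4 (0.23 log units; within the scatter), the first direct reading of this position. A 4-methoxyphenyl in place of phenyl is thus accepted here alongside the 2-methoxyphenyl amine, with no step beyond the scatter. Nothing measured on these compounds bears on the reason for this result.

From the compounds shown here alone, whether a hydroxy group or a dimethylamino group at this place would give a step beyond the scatter remains open, as does whether the methoxy step reads the same with a benzyl group on the amine nitrogen.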